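Piperazine dithiocarbamate pair: phenyl for pyridinylmethyl

A few compounds are considered here, and "the series" means these few. Any claim that something is new, unique, unknown or untested is made for them only; others in the source may bear on it.

Two compounds have numbers. Compound 1 `CCN(Cc1ccncc1)C(=S)SCc1ccc(C(=O)Nc2ccccc2N)cc1` gives 71.6% in a functional assay on MGC-803 cells (Homo sapiens) for antiproliferative activity, read by CCK-8 assay, with a stated time of 72 h, tested at 2 uM; a lower number here means a weaker effect, a higher number a stronger effect of the compound at the concentration tested. Compound 2 `Nc1ccccc1NC(=O)c1ccc(CSC(=S)N2CCN(Cc3ccncc3)CC2)cc1` gives 18.4%, the lowest of the two, a gap beyond the scatter. Compound 3 `Nc1ccccc1NC(=O)c1ccc(CSC(=S)N2CCN(c3ccccc3)CC2)cc1` is not yet measured; it differs from compound 2 by phenyl in place of (pyridin-4-yl)methyl on an amine nitrogen in a ring. Within the data shown here, no measured pair shows the effect of such a change, so the size of the step is uncertain. A modest increase in this assay is expected, and a step within the scatter cannot be excluded. For compound 3 the estimate is 30%, between 10% and 60%. This estimate means a step of a number 11.6 percentage points higher from compound 2 to compound 3 (beyond the scatter).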

Compound 3, a percentage reported as inhibition, at one concentration (the size of the read-out at that concentration, not a potency): 42.3%
Estimate against measurement, compound 3: 12.3 percentage points below; the measured number falls inside the stated range.
By their numbers in this assay, from the lowest: compound 2; then compound 3; then compound 1.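

In this assay, phenyl in place of (pyridin-4-yl)methyl on the amine nitrogen in a ring gives a number 23.9 percentage points higher from compound 2 to compound 3 (beyond the scatter) and so shows that the group at this position changes the read-out. The change alters two things together, the ring nitrogen of the pyridine and the methyl link, and this single step cannot separate them. No measured evidence accounts for the rise.

Open, going by these compounds, is where benzyl, which keeps the link on a carbon-only ring, or pyridin-4-yl, attached directly without the link, would fall relative to compound 2 and compound 3. Either group would help to separate the contributions of the link and the pyridine nitrogen.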